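Moving the phenyl closer and adding an isobutyl

This account rests on a few compounds, and the source may have more. Where it says the series, first, only, none or still open, it means among the compounds named here.

Of the compounds shown here, three sharing one core have been measured in an assay for inhibition of acyl-CoA:cholesterol acyltransferase (Oryctolagus cuniculus), using microsomes; a higher number here means a weaker inhibitor, a lower number a stronger inhibitor. Compound 1 `Cc1cc(C)c(NC(=O)C(C)(C)CCCCCCN2CCCCC2)c2c1CC(C)(C)O2` carries a piperidine ring at the far end of its chain; in this assay compound 1 gives > 500 nM, which is a limit of the assay and not a number. Compound 2 `Cc1cc(C)c(NC(=O)C(C)(C)CCCCc2ccccc2)c2c1CC(C)(C)O2` ends in a phenyl instead, and in this assay compound 2 gives 210 nM. Compound 3 `Cc1cc(C)c(NC(=O)C(C)(C)CCCCCCc2ccccc2)c2c1CC(C)(C)O2`, with phenethyl in place of phenyl, gives 81 nM in this assay, the lowest of the two numbers; the step of a 2.6-fold lower number from compound 2 to compound 3 (0.41 log units; beyond the scatter) is beyond the scatter, as are an at least 2.3-fold lower number from compound 1 to compound 2 (0.37 log units; beyond the scatter) and an at least 6.1-fold lower number from compound 1 to compound 3 (0.79 log units; beyond the scatter).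

Compound 4 `Cc1cc(C)c(NC(=O)C(C)(C)CCCc2ccc(CC(C)C)cc2)c2c1CC(C)(C)O2` has not yet been measured. It differs from compound 3 by 4-isobutylphenyl in place of 3-phenylpropyl on a saturated chain carbon, four bonds along the chain from a carbonyl carbon. The phenyl thus sits nearer to the carbonyl, as it does in compound 2, while the isobutyl on the ring keeps the overall reach of the side chain close to that of compound 3. Within the data shown here, the step of a 2.6-fold lower number from compound 2 to compound 3 (0.41 log units; beyond the scatter) bears most directly on this change, and no measured compound carries a substituent on the phenyl ring. The step to compound 4 is expected to be a 1.9-fold higher number from compound 3 to compound 4 (0.27 log units; within the scatter), within the scatter. The estimate for compound 4 in this assay is 150 nM, with a range from 50 nM to 450 nM.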

Compound 4, half-maximal inhibitory concentration: 40 nM
Compound 4: the middle estimate sits 3.8-fold (0.57 log units) above what was measured; measured number outside the range, below it.
By their numbers in this assay, from the lowest: compound 4; then compound 3; then compound 2. At a limit, above all of these: compound 1.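

In this assay, among these compounds, 4-isobutylphenyl in place of 3-phenylpropyl gives a 2.0-fold lower number from compound 3 to compound 4 (0.31 log units; beyond the scatter), so the longest unsubstituted chain no longer marks the lowest number, and for the first time a compound with a group on the phenyl ring itself can be read. The earlier pair suggested that lengthening the chain lowers the number, and compound 4, with its shorter chain and isobutyl-bearing ring, goes against that simple reading, with a 5.3-fold lower number from compound 2 to compound 4 (0.72 log units; beyond the scatter). The largest step, an at least 12-fold lower number from compound 1 to compound 4 (1.09 log units; beyond the scatter), rests on a limit of the assay and not a number, the one held by compound 1, so its true size stays unknown: the limit of > 500 nM in this assay, at which 1 of the 4 values shown sits.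

Going by these compounds, what remains open is how much of the improvement belongs to the isobutyl and how much to the shorter chain, as the two change together in compound 4. Also open, on these data alone, is whether a methyl, a methoxy or a carboxylic acid in place of the isobutyl would keep the number this low, and whether an isobutyl on the ring of the longer chain of compound 3 would lower it further.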